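Cytotoxicity in BJ cells: chloro in place of methoxy

The source may report more compounds than this note shows. Statements on the series, on what has been measured and on what is new or still open speak of the compounds shown alone.

Measured so far in an ADME assay on BJ cells (Homo sapiens) for cytotoxicity, read by luminescence, with a stated time of 72 h; a lower number here means that less compound is needed, a higher number that more compound is needed for the effect:
compound 1, `CCOC(=O)c1c(-c2cccc(OC)c2)[nH]c2cc(OC)ccc2c1=O`: > 21500 nM, a limit of the assay.
compound 2, `CCOC(=O)c1c(-c2cccc(Cl)c2)[nH]c2cc(OC)ccc2c1=O`: > 21500 nM, a limit of the assay.
compound 3, `CCOC(=O)c1c(-c2cccc(-c3ccccc3)c2)[nH]c2cc(OC)c(OC)cc2c1=O`: > 21500 nM, a limit of the assay.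

Compound 2 differs from compound 1 by chloro in place of methoxy on an aromatic carbon, and in this assay this gives a step that the two limits leave unreadable from compound 1 to compound 2. How the core of compound 3 differs from the core of compound 1 is not broken down here.

Compound 4, `CCOC(=O)c1c(-c2cccc(-c3ccccc3)c2)[nH]c2cc(Cl)c(OC)cc2c1=O`, is not yet measured and differs from compound 3 by chloro in place of methoxy on an aromatic carbon. The surroundings are not the same as in the earlier pair: there the carbon was meta to a large group, here it is part of a fused or bridged system of two rings, ortho to a methoxy group, meta to a fused ring and para to a fused ring, so this is the same kind of change, not the same change.

For this assay the expectation for compound 4 rests on (the limit of > 21500 nM in this assay, at which 3 of the 3 values shown sit), and the step is expected to be a step that the limit leaves unreadable from compound 3 to compound 4. Compound 4 is therefore estimated at 30000 nM, between 12000 nM and 100000 nM, most likely reported again only as a limit.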

Compound 4, half-maximal effective concentration: > 21500 nM
Compound 4: only a limit was reported; the forecaster's own chance of this, stated with the estimate: 85%; the middle value lies beyond the limit too.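

No step can be read from compound 3 to compound 4 in this assay, as both are reported only as limits of the assay. The compounds shown leave open what chloro in place of methoxy does here, and at what concentration any of them would reach the half-maximal effect: the limit of > 21500 nM in this assay, at which 4 of the 4 values shown sit.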